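The source may report more compounds than this note shows. Statements on the series, on what has been measured and on what is new or still open speak of the compounds shown alone.

In a functional assay on Hs-578T cells (Homo sapiens) for antiproliferative activity, read by WST assay, with a stated time of 48 h (a higher number here means a weaker inhibitor of growth, a lower number a stronger inhibitor of growth), compound 1 (`CCCCC/C=C/c1c(O)ccc(O)c1CO`) gives 59700 nM. Compound 2 (`CCCCCC[C@H](O)c1c(O)ccc(O)c1CO`) is recorded only as a limit of the assay, > 100000 nM. Compound 3 (`CCCCCC[C@@H](O)c1c(O)ccc(O)c1CO`) has the same atoms and bonds as compound 2 and differs from it in configuration alone: the two compounds have the same atoms and bonds and differ only in configuration as drawn: 1 of 1 stereo elements differ; a stereocentre at a saturated chain carbon is drawn S in compound 2 and R in compound 3. Among the measured compounds shown here, no measured pair shows what such a change does in this assay, so little movement is assumed. The expected step, a number no higher from compound 2 to compound 3 (the limit leaves the size open), is estimated to be none beyond the scatter, leaving growth inhibition weak. For compound 3 the estimated value is 100000 nM, with an expected range of 55000 nM to 180000 nM.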

Compound 3, concentration for 50% growth inhibition: > 100000 nM
Compound 3: a limit, no number; the forecaster's own chance of this, stated with the estimate: 55%; the middle value lies on the limit itself.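

Among the compounds shown here, compound 2 and compound 3 are both recorded only as limits in this assay, so no step between them can be read. Going by these compounds, whether the S or R configuration at the saturated chain carbon affects growth inhibition remains open.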